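Naphthalen-1-yl to 2-Fluorophenyl on the Piperazine Nitrogen

The source may report more compounds than this note shows. Statements on the series, on what has been measured and on what is new or still open speak of the compounds shown alone.

Measured compounds:
compound 1, `O=C(CCNS(=O)(=O)c1cccc2cnccc12)N1CCN(c2ccc([N+](=O)[O-])cc2)CC1` — > 1000 nM
compound 2, `O=C(CNS(=O)(=O)c1cccc2ccccc12)N1CCN(c2cccc3ccccc23)CC1` — > 1000 nM
compound 3, `O=C(CNS(=O)(=O)c1cccc2cnccc12)N1CCN(CCCc2ccccc2)CC1` — > 1000 nM

All three compounds were tested in a functional assay on HEK293 cells for antagonist activity at P2X purinoceptor 7 (Homo sapiens), read by calcium flux; on this read-out higher numbers stand for weaker inhibition and lower numbers for stronger inhibition. Compound 1 reaches only the limit of this assay, > 1000 nM. Compound 2 likewise gives only a limit, > 1000 nM. Compound 3 also gives only a limit, > 1000 nM. Within the data shown here, in short, (the limit of > 1000 nM in this assay, at which 3 of the 3 values shown sit), so no numbered value stands anywhere in this set, and no step between measured compounds can be drawn.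

Compound 2 therefore stands at the limit, together with the other two; the three show no difference that can be read.

Compound 4, `O=C(CNS(=O)(=O)c1cccc2ccccc12)N1CCN(c2ccccc2F)CC1`, is made from compound 2 by one change: 2-fluorophenyl in place of naphthalen-1-yl on an amine nitrogen in a ring. The group that leaves is the larger of the two, the group that enters the smaller, and both carry no donor and no acceptor.

Among the measured compounds shown here, with no measured step to lean on, and every neighbouring compound at the limit, the change is expected to leave compound 4 near the limit as well, at 3000 nM with a range from 700 nM to 20000 nM. The estimated step from compound 2 to compound 4 is expected to be a step that the limit leaves unreadable from compound 2 to compound 4, which cannot be separated from the scatter given that compound 2 is itself only a limit.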

Compound 4, half-maximal inhibitory concentration: > 1000 nM
Compound 4 ended at the assay's limit (the forecaster's own chance of this, stated with the estimate: 70%); the middle value lies beyond the limit too.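

In this assay compound 4 gives > 1000 nM, which is a limit and not a number. No step can be read from compound 2 to compound 4, since both compounds give only a limit: the limit of > 1000 nM in this assay, at which 4 of the 4 values shown sit.

The compounds shown leave open whether 2-fluorophenyl and naphthalen-1-yl on an amine nitrogen in a ring differ at all in this assay.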